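A few compounds are considered here, and "the series" means these few. Any claim that something is new, unique, unknown or untested is made for them only; others in the source may bear on it.

The measured compounds in a functional assay on T47D cells (Homo sapiens) for inhibition, read by sulforhodamine B assay, with a stated time of 48 h, tested at 10 uM (a lower number here means a stronger effect, a higher number a weaker effect of the compound at the concentration tested), are as follows:
compound 1 `COc1cc(Cl)cc(-c2nn(-c3cccc(NC(=O)Nc4ccc(Cl)c(C(F)(F)F)c4)c3)cc2-c2ccncc2)c1` gives 8.1%;
compound 2 `COc1cc(Cl)cc(-c2nn(-c3cccc(NC(=O)c4cccc(C(F)(F)F)c4)c3)cc2-c2ccncc2)c1` gives 36.6%;
compound 3 `O=C(Nc1cccc(-n2cc(-c3ccncc3)c(-c3cc(O)cc(Cl)c3)n2)c1)c1cc(C(F)(F)F)cc(C(F)(F)F)c1` gives 26.3%.

Among these three numbers, compound 3 holds the second highest place. Its nearest neighbour is compound 2, whose number sits higher by more than the usual scatter, while compound 1 lies lower, again beyond the scatter. Compound 4 `COc1cc(Cl)cc(-c2nn(-c3cccc(NC(=O)c4cc(C(F)(F)F)cc(C(F)(F)F)c4)c3)cc2-c2ccncc2)c1` has not yet been measured. It differs from compound 3 in one place: methyl in place of hydrogen on an oxygen on an aromatic ring. For the measured compounds named here, the only measured step, a number 28.5 percentage points higher from compound 1 to compound 2 (beyond the scatter), concerns the group attached to the carbonyl carbon and not the oxygen on the aromatic ring, so it says nothing directly about this change. Going by the values given here, compounds 1 and 2 both carry the methoxy group and compound 3 carries the hydroxy group, but no pair among the three isolates that difference alone, so the effect of the swap has not been tested on its own. Without a guiding step, the expected move is a number 1.7 percentage points higher from compound 3 to compound 4 (within the scatter) in this assay, that is, no step beyond the scatter. Compound 4 is therefore estimated at 28%, within a range from 12% to 48%.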

Compound 4, a percentage reported as activity, at one concentration (the size of the read-out at that concentration, not a potency): 53.4%
Beside the measured number, compound 4's estimate is 25.4 percentage points below it; measured number above the stated range.
By their numbers in this assay, from the lowest: compound 1; then compound 3; then compound 2; then compound 4.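

Turning hydroxy into methoxy on the 3-chloro-5-hydroxyphenyl group gives a number 27.1 percentage points higher from compound 3 to compound 4 (beyond the scatter) in this assay and thus a weaker effect at the concentration tested, so this oxygen is not a place where the swap goes unnoticed. For the compounds shown here, this is the first reading of that change on its own, as compounds 1 and 2 could not separate it from other differences. A second single change also weakens the effect: trifluoromethyl in place of hydrogen on an aromatic carbon gives a number 16.8 percentage points higher from compound 2 to compound 4 (beyond the scatter) when the methoxy group is kept, and this step and the methyl step are each seen only once, on one pair of compounds. Nothing available here explains why either change moves the number as it does.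

As far as these compounds go, whether the weakening grows with size at this oxygen stays open, since an ethoxy group or a longer chain there would be needed to tell, and an amine in place of the hydroxy would ask whether the oxygen itself matters. From the compounds shown here alone, it is also open whether the hydroxy to methoxy step keeps its size on a different amide or urea side of the molecule.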